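Aryl hydrazone variation on a shared core

The compounds below may be only part of what the source reports. "The series", "measured", "known", "first", "only" and "open" are said of these compounds alone.

Compound 1 `COc1ccc(/C=N/NC(=O)Nc2ccc(Oc3ccnc(-c4nncn4CCN(C)C)c3)c(F)c2)c(OC)c1OC` holds the lowest number of the three measured in a functional assay on MKN-45 cells (Homo sapiens) for cytotoxicity, read by MTT assay, with a stated time of 72 h (on this read-out higher numbers stand for weaker inhibition and lower numbers for stronger inhibition), at 2020 nM, though compound 2 sits within the scatter of it. Compound 2 `CN(C)CCn1cnnc1-c1cc(Oc2ccc(NC(=O)N/N=C/c3ccc(O)c(O)c3)cc2F)ccn1` gives 3240 nM and compound 3 `CN(C)CCn1cnnc1-c1cc(Oc2ccc(NC(=O)N/N=C/c3cc(Br)c(O)c(Br)c3)cc2F)ccn1` gives 4320 nM. The steps from the common parent are a 1.6-fold higher number from compound 1 to compound 2 (0.21 log units; within the scatter) and a 2.1-fold higher number from compound 1 to compound 3 (0.33 log units; beyond the scatter); between the two analogues, a 1.3-fold higher number from compound 2 to compound 3 (0.12 log units; within the scatter). Compound 4 `CN(C)CCn1cnnc1-c1cc(Oc2ccc(NC(=O)N/N=C/c3ccc(Cl)cc3)cc2F)ccn1` differs from compound 1 by 4-chlorophenyl in place of 2,3,4-trimethoxyphenyl on a carbon with a double bond to nitrogen. Both measured aryl replacements bear on this change and neither moved the number by more than a modest amount, so for compound 4 a small upward step or none beyond the scatter is expected: a 1.5-fold higher number from compound 1 to compound 4 (0.17 log units; within the scatter). Compound 4 is estimated at 3000 nM, with a range from 1400 nM to 6500 nM.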

Compound 4, half-maximal inhibitory concentration: 570 nM
For compound 4 the middle estimate is 5.3-fold (0.72 log units) above the measured one, and the stated range ends above it.
By their numbers in this assay, from the lowest: compound 4; then compounds 1, 2 and 3 (each within the scatter of the next, the first and the last beyond it).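

In this assay, the aryl group on a carbon with a double bond to nitrogen can lower the number: 4-chlorophenyl gives a 3.5-fold lower number from compound 1 to compound 4 (0.55 log units; beyond the scatter), whereas neither earlier replacement gave a step down beyond the scatter. Against the other two analogues the change gives a 5.7-fold lower number from compound 2 to compound 4 (0.75 log units; beyond the scatter) and a 7.6-fold lower number from compound 3 to compound 4 (0.88 log units; beyond the scatter), so this position spans a wider range than the first three compounds indicated. Nothing available explains the gain.

Still open, as far as these compounds go, is whether the chlorine itself carries the step or the absence of oxygen substituents does. An unsubstituted phenyl, 4-methylphenyl or a phenyl bearing an amine would help separate these readings.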